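The source may hold more compounds than are shown below. What is called first, only, known or untested is meant among the compounds shown, and "the series" means these compounds.

For the measured compounds named here, in a functional assay on IGROV-1 cells (Homo sapiens) for antiproliferative activity, read by sulforhodamine B assay, with a stated time of 48 h (on this read-out lower numbers stand for stronger inhibition of growth and higher numbers for weaker inhibition of growth), compound 1 (`O=C(NCCCNc1cc(-c2cn(-c3ccccc3)nc2-c2cccc(O)c2)ccn1)Nc1ccc(F)cc1`) gives 5820 nM and compound 2 (`O=C(NCCCNc1cc(-c2cn(-c3ccccc3)nc2-c2cccc(O)c2)ccn1)Nc1cccc(C(F)(F)F)c1`) gives 7980 nM so the only two numbers available lie within the scatter of each other. Compound 3 (`COc1cccc(-c2nn(-c3ccccc3)cc2-c2ccnc(NCCCNC(=O)Nc3ccc(F)cc3)c2)c1`) differs from compound 1 in one place, where 3-hydroxyphenyl becomes 3-methoxyphenyl (methyl in place of hydrogen on an oxygen on an aromatic ring) with methyl in place of hydrogen on an oxygen on an aromatic ring. Going by the values given here, the single measured step (a 1.4-fold higher number from compound 1 to compound 2 (0.14 log units; within the scatter)) lies within the scatter but concerns another site, an amide-type nitrogen. Among the compounds with values here, no measured pair covers the hydroxy to methoxy change, so its direction remains open and no step beyond the scatter is expected. The estimated step is small (a 1.2-fold higher number from compound 1 to compound 3 (0.08 log units; within the scatter)) and carries little weight. Compound 3 is estimated at 7000 nM with an expected range from 3000 nM to 16000 nM for this value.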

Compound 3, concentration for total growth inhibition: > 37000 nM
Compound 3 was reported as a limit; the forecaster's own chance of this, stated with the estimate: 10%; middle value at least 5.2-fold (0.72 log units) away from the limit.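

Methyl in place of hydrogen on an oxygen on an aromatic ring gives an at least 6.3-fold higher number from compound 1 to compound 3 (0.80 log units; beyond the scatter), the first step in this series beyond the scatter, whereas the change on the amide-type nitrogen gave a 1.4-fold higher number from compound 1 to compound 2 (0.14 log units; within the scatter). Compound 3 stands in this assay only as a limit and not as a number: the limit of > 37000 nM in this assay, at which 1 of the 3 values shown sits. In this single pair, the 3-hydroxyphenyl group goes with the stronger inhibition of growth, so this position responds to a change that adds only a methyl.

On these data alone, how far the step extends past the limit cannot be read, and the same change on compound 2 remains open. As far as these compounds go, whether any replacement of the hydroxy group has this outcome also remains open, as an amine or an ethoxy group at this place could show.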